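The compounds below may be only part of what the source reports. "The series", "measured", "known", "first", "only" and "open" are said of these compounds alone.

In a functional assay on SGC-7901 cells (Homo sapiens) for antiproliferative activity, read by MTT assay, with a stated time of 48 h (on this read-out higher numbers stand for weaker inhibition and lower numbers for stronger inhibition), compound 2 `Clc1ccc(-c2nnc(SCc3ccc(Cl)nc3)o2)cc1` gives 8.62 ug/mL and compound 1 `CCOc1ccc(-c2nnc(SCc3ccc(Cl)nc3)o2)cc1` gives 4.97 ug/mL. Among the compounds with values here, these two numbers lie within the usual scatter of each other, so compound 2 cannot be ranked against the only other compound measured. Compound 3 `Oc1ccc(-c2nnc(SCc3ccc(Cl)nc3)o2)cc1` keeps the shared core and differs from compound 2 in one group, with hydroxy in place of chloro on an aromatic carbon, para to a large group (hydroxy in place of chloro on an aromatic carbon). Within the data shown here, one measured step bears on this place: a 1.7-fold higher number from compound 1 to compound 2 (0.24 log units; within the scatter), with chloro in place of ethoxy. Hydroxy itself has not been measured there, so the evidence is thin. Among the measured compounds shown here, with a 1.7-fold higher number from compound 1 to compound 2 (0.24 log units; within the scatter) as the only guide, no step beyond the scatter is expected in this assay, and no firm direction. The expected step is a 1.3-fold lower number from compound 2 to compound 3 (0.12 log units; within the scatter). For compound 3 the estimated value is 6.5 ug/mL, with an expected range from 2.5 ug/mL to 17 ug/mL.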

Compound 3, half-maximal inhibitory concentration: > 20 ug/mL
Compound 3 ended at the assay's limit; the forecaster's own chance of this, stated with the estimate: 3%; at least 3.0-fold (0.48 log units) between middle value and limit.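

Compounds 1 and 2 could not be told apart in this assay, so this place, para to a large group, had shown no clear effect on the read-out. Compound 3 changes that: with hydroxy in place of chloro there is an at least 2.3-fold higher number from compound 2 to compound 3 (0.36 log units; beyond the scatter), and with hydrogen in place of ethyl on the oxygen there is an at least 4.0-fold higher number from compound 1 to compound 3 (0.60 log units; beyond the scatter). The value of compound 3 is a limit of the assay and not a number: the limit of > 20 ug/mL in this assay, at which 1 of the 3 values shown sits.

Going by these compounds, how much weaker compound 3 really is therefore stays open. The compounds shown also cannot tell whether an amine or a carboxylic acid at this place would behave like hydroxy, or how a longer chain on the oxygen would compare with ethoxy.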